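Diethylamino in Place of Dimethylamino: Expecting Compound 4

The source may hold more compounds than are shown below. What is called first, only, known or untested is meant among the compounds shown, and "the series" means these compounds.

The measured compounds and their values:
Compound 1, `CN(C)CCCn1c(N)c(-c2nc3ccccc3[nH]2)c2nc(C#N)c(C#N)nc21`, gives in a functional assay on A549 cells (Homo sapiens) for antiproliferative activity, read by MTT assay, with a stated time of 48 h (on this read-out lower numbers stand for stronger inhibition and higher numbers for weaker inhibition), a value of 10400 nM.
Compound 2, `CCN(CC)CCCn1c(N)c(-c2nc3ccccc3[nH]2)c2nc(C#N)c(C#N)nc21`, gives in this assay a value of 25300 nM.
Compound 3, `CN(C)CCn1c(N)c(-c2nc3cc(Cl)ccc3[nH]2)c2nc(C#N)c(C#N)nc21`, gives in this assay only a limit of the assay, > 50000 nM.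

Compound 1 and compound 2 differ in one place: diethylamino in place of dimethylamino on a saturated chain carbon, three bonds along the chain from an aromatic nitrogen. That change gave a 2.4-fold higher number from compound 1 to compound 2 (0.39 log units; beyond the scatter).

Compound 4, `CCN(CC)CCn1c(N)c(-c2nc3cc(Cl)ccc3[nH]2)c2nc(C#N)c(C#N)nc21`, has not been measured. It differs from compound 3 in one place: diethylamino in place of dimethylamino on a saturated chain carbon, two bonds along the chain from an aromatic nitrogen. This is the same kind of change as that from compound 1 to compound 2, but the place is not the same: there the diethylamino stands three bonds along the chain from an aromatic nitrogen, here two bonds along. How the core of compound 3 differs from the core of compound 1 is not broken down here.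

Compound 3 already sits at the limit, (the limit of > 50000 nM in this assay, at which 1 of the 3 values shown sits). Since the same kind of change weakened compound 1 to compound 2 by a 2.4-fold higher number from compound 1 to compound 2 (0.39 log units; beyond the scatter), compound 4 is expected to stay at or beyond that limit, an expected step that the limit leaves unreadable from compound 3 to compound 4. The expected value for compound 4 in this assay is 90000 nM, between 40000 nM and 250000 nM.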

Compound 4, half-maximal inhibitory concentration: > 50000 nM
Compound 4 gave a limit, no number; the forecaster's own chance of this, stated with the estimate: 85%; the middle value lies beyond the limit too.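

Compound 3 and compound 4 both give only a limit in this assay, not a number, so no step between them can be read: the limit of > 50000 nM in this assay, at which 2 of the 4 values shown sit.

On these data alone, what stays open is whether diethylamino in place of dimethylamino changes the read-out at all on the core of compound 3, where neither compound gives a number.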